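This account rests on a few compounds, and the source may have more. Where it says the series, first, only, none or still open, it means among the compounds named here.

Of the compounds shown here, two have been measured in a functional assay on HCT-15 cells (Homo sapiens) for inhibition, read by sulforhodamine B assay, with a stated time of 48 h, tested at 10 uM; on this read-out higher numbers stand for more inhibition at the one concentration tested (going by the name of the read-out) and lower numbers for less inhibition. Compound 1 `Cc1cccc(-c2cn3ccnc3c(-c3ccc4ncn(Cc5ccccc5)c4c3)n2)c1` gives 35.2%. Compound 2 `c1cn2cc(-c3ccc4c(c3)ncn4C3CCCCC3)nc(-c3ccc4ncn(C5CCCCC5)c4c3)c2n1` gives 35.6%, and compound 1 lies within the usual scatter of it, so the two cannot be told apart on these numbers. Compound 3 `c1ccc(Cn2cnc3ccc(-c4nc(-c5ccc6c(c5)ncn6C5CCCCC5)cn5ccnc45)cc32)cc1` is the next compound, differing from compound 2 by benzyl in place of cyclohexyl on an aromatic nitrogen. Within the data shown here, no measured pair shows a single change of this kind, so there is no step to lean on. The change is expected to give no step beyond the scatter, a number 0.6 percentage points lower from compound 2 to compound 3 (within the scatter), and compound 3 is estimated at 35%, between 20% and 50%.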

Compound 3, a percentage reported as inhibition, at one concentration (the size of the read-out at that concentration, not a potency): -9.03%
Compound 3: middle estimate off by 44 percentage points, on the high side, and the stated range ends above it.
By their numbers in this assay, from the lowest: compound 3; then compounds 1 and 2 (each within the scatter of the next).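

At this position on the aromatic nitrogen, the choice of group matters: in this assay, putting benzyl in place of cyclohexyl gives a number 44.6 percentage points lower from compound 2 to compound 3 (beyond the scatter) and leaves a clear gap in the read-out. Both groups hold one six-membered ring of carbon only and neither has a hydrogen-bond donor or acceptor, so these counts alone do not predict the outcome. Nothing available explains the size of this step.

The compounds shown leave open how a phenethyl group, a longer alkyl chain or a chain ending in an amine would behave on this nitrogen. They also leave open whether a smaller group, such as methyl, would match compound 2 or fall closer to compound 3.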